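A few compounds are considered here, and "the series" means these few. Any claim that something is new, unique, unknown or untested is made for them only; others in the source may bear on it.

The three measured compounds share one core and were compared in a functional assay on Hep 3B2 cells (Homo sapiens) for antiproliferative activity, read by MTT assay, with a stated time of 24 h, tested at 1.23 ug/mL; on this read-out higher numbers stand for a stronger effect at the one concentration tested and lower numbers for a weaker effect. Compound 1 `Cc1ccc2nc(C(=O)Nc3c(F)cc(-c4cccc(F)c4)cc3F)c(C)c(O)c2c1` gives 11.2% there. Compound 2 `CCc1ccc2nc(C(=O)Nc3c(F)cc(-c4cccc(F)c4)cc3F)c(C)c(O)c2c1` gives 23.5% in this assay, and compound 3 `Cc1ccc2nc(C(=O)Nc3c(F)cc(-c4cccc(F)c4)cc3F)c(C)c(C(=O)O)c2c1` gives 21.3% in this assay. Among these three numbers compound 3 stands second highest: the step of a number 10.1 percentage points higher from compound 1 to compound 3 (beyond the scatter) lies beyond the scatter, whereas its gap to compound 2 lies within it. Compound 4 `CCc1ccc2nc(C(=O)Nc3c(F)cc(-c4cccc(F)c4)cc3F)c(C)c(C(=O)O)c2c1` differs from compound 3 by methyl in place of hydrogen on a saturated chain carbon bound to an aromatic carbon. One measured step is of exactly this kind, a number 12.3 percentage points higher from compound 1 to compound 2 (beyond the scatter), modest yet beyond the scatter, so a rise of similar size is expected here. Compound 4 is therefore expected to give 31% in this assay, with a range from 18% to 44%. This amounts to an expected step of a number 9.7 percentage points higher from compound 3 to compound 4 (within the scatter).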

Compound 4, a percentage reported as inhibition, at one concentration (the size of the read-out at that concentration, not a potency): 4.52%
Beside the measured number, compound 4's estimate is 26.5 percentage points above it, outside the stated range (below it).
By their numbers in this assay, from the lowest: compounds 4 and 1 (each within the scatter of the next); then compounds 3 and 2 (each within the scatter of the next).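

In this assay, methyl in place of hydrogen on a saturated chain carbon bound to an aromatic carbon has no fixed effect, since with carboxy on the core it gives a number 16.8 percentage points lower from compound 3 to compound 4 (beyond the scatter), against the rise seen with hydroxy: the same change on two cores in this assay, a number 12.3 percentage points higher (beyond the scatter) from compound 1 to compound 2 and a number 16.8 percentage points lower (beyond the scatter) from compound 3 to compound 4, 29.1 percentage points apart, beyond the scatter of two such steps Carboxy in place of hydroxy likewise depends on the chain, giving a number 19 percentage points lower from compound 2 to compound 4 (beyond the scatter) where the chain is ethyl: the same change on two cores in this assay, a number 10.1 percentage points higher (beyond the scatter) from compound 1 to compound 3 and a number 19 percentage points lower (beyond the scatter) from compound 2 to compound 4, 29.1 percentage points apart, beyond the scatter of two such steps The two changes therefore do not add up across these four compounds. On these data alone, whether a longer chain such as propyl, or an amide in place of carboxy, follows the same turn remains open.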